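Ethylsulfonylamino in Place of Methylcarbamoyl on a Shared Core

A few compounds are considered here, and "the series" means these few. Any claim that something is new, unique, unknown or untested is made for them only; others in the source may bear on it.

Of the compounds shown here, three built on one shared core have been tested in a functional assay on CHO cells for agonist activity at Alpha-1A adrenergic receptor (Homo sapiens), read by FLIPR and calcium flux; a higher number here means a larger maximal response, a lower number a smaller maximal response. Compound 1 `CS(=O)(=O)Nc1cccc2c1CCC2c1ncc[nH]1` carries a methanesulfonamido group, and in this assay compound 1 gives 87%. Compound 2 `Cn1cc(-c2cccc3c2CCC3c2ncc[nH]2)cn1` carries a 1-methyl-1H-pyrazol-4-yl group in that position, and compound 2 gives 12%. Compound 3 `CNC(=O)c1cccc2c1CCC2c1ncc[nH]1` carries a methylcarbamoyl group, and compound 3 gives 59%. Among these three numbers compound 3 stands second highest: the step of a number 28 percentage points lower from compound 1 to compound 3 (beyond the scatter), while the step of a number 47 percentage points higher from compound 2 to compound 3 (beyond the scatter). The widest gap is the step of a number 75 percentage points lower from compound 1 to compound 2 (beyond the scatter).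

Compound 4 `CCS(=O)(=O)Nc1cccc2c1CCC2c1ncc[nH]1` has not yet been measured. It differs from compound 3 in a single place: (ethylsulfonyl)amino in place of methylcarbamoyl on an aromatic carbon. The entering group resembles the methanesulfonamido group of compound 1, with ethyl in place of methyl on the sulfonyl part. The step of a number 28 percentage points lower from compound 1 to compound 3 (beyond the scatter) shows that swapping a sulfonamide of this kind for methylcarbamoyl cost a modest amount, so reversing that swap from compound 3 should regain a similar amount. For compound 4 the expected step is a number 24 percentage points higher from compound 3 to compound 4 (beyond the scatter). The estimate for compound 4 is 83%, with a range from 65% to 100%.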

Compound 4, largest response reached (Emax), in percent of the reference or control that the assay uses: 86%
Compound 4: the middle estimate sits 3 percentage points below what was measured; measured number inside the range.
By their numbers in this assay, from the lowest: compound 2; then compound 3; then compounds 4 and 1 (each within the scatter of the next).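

In this assay, ethyl in place of methyl on the sulfonyl part leaves no change that can be told apart: the step of a number 1 percentage points lower from compound 1 to compound 4 (within the scatter) shows that, at this place on the aromatic carbon, the sulfonamide group can carry either of these two small chains with the same result. The advantage of the sulfonamide group over the other two groups also survives this change, as shown by the step of a number 27 percentage points higher from compound 3 to compound 4 (beyond the scatter) and the larger step of a number 74 percentage points higher from compound 2 to compound 4 (beyond the scatter), so it does not depend on the methyl of compound 1 alone. No measurement is available that explains why either sulfonamide gives a larger maximal response than methylcarbamoyl or 1-methyl-1H-pyrazol-4-yl.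

With only methyl and ethyl on the sulfonyl part, the compounds shown cannot say how far this tolerance extends, for instance to a propyl or longer chain, or to a phenyl ring. They also leave open whether the hydrogen on the sulfonamide nitrogen matters, which a methyl in its place could test, and how a carboxylic acid at the same place would compare.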